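The source may hold more compounds than are shown below. What is called first, only, known or untested is meant among the compounds shown, and "the series" means these compounds.

Compound 1 `O=S(=O)(c1cc(Cl)cc(Cl)c1)c1cnc2c(F)cccc2c1-c1ccccc1F` and compound 2 `COc1cccc(-c2c(S(=O)(=O)c3cc(Cl)cc(Cl)c3)cnc3c(F)cccc23)c1` share one core and differ only at a single aromatic carbon. In an ADME assay on microsomes from liver (Homo sapiens) for metabolic stability, tested at 2.5 uM (a lower number here means slower removal, a higher number faster removal of the compound), compound 2 gives 2.31 mL/min, while compound 1 gives 0.44 mL/min; the change 2-fluorophenyl in place of 3-methoxyphenyl on an aromatic carbon produced a 5.3-fold lower number from compound 2 to compound 1 (0.72 log units; beyond the scatter). Compound 3 `COc1cccc(-c2c(S(=O)(=O)c3cccc(C#N)c3)cnc3cc(F)ccc23)c1` gives 1.83 mL/min in this assay, a number within the usual scatter of that of compound 2 and beyond the scatter above that of compound 1. The difference between the cores of compound 2 and compound 3 is not broken down here. Compound 4 `N#Cc1cccc(S(=O)(=O)c2cnc3cc(F)ccc3c2-c2ccccc2F)c1` has not been measured; it arises from compound 3 by 2-fluorophenyl in place of 3-methoxyphenyl on an aromatic carbon, the same kind of change as from compound 2 to compound 1, at the same kind of place. Within the data shown here, the earlier instance a 5.3-fold lower number from compound 2 to compound 1 (0.72 log units; beyond the scatter) is the only guide. For compound 4 a step of a 4.1-fold lower number from compound 3 to compound 4 (0.61 log units; beyond the scatter) is expected. Compound 4 is therefore estimated at 0.45 mL/min, between 0.2 mL/min and 1 mL/min.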

Compound 4, intrinsic clearance in a liver preparation (reported as CLH), per the amount of preparation that the assay uses: 1.39 mL/min
Compound 4: middle estimate off by 3.1-fold (0.49 log units), on the low side, outside the stated range (above it).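

In this assay, putting 2-fluorophenyl in place of 3-methoxyphenyl gives a 1.3-fold lower number from compound 3 to compound 4 (0.12 log units; within the scatter) on this core. The size of the step therefore did not carry over from the core of compound 2 to the core of compound 3: the same change on two cores in this assay, a 5.3-fold lower number (0.72 log units; beyond the scatter) from compound 2 to compound 1 and a 1.3-fold lower number (0.12 log units; within the scatter) from compound 3 to compound 4, 4.0-fold (0.60 log units) apart, beyond the scatter of two such steps. This shows that a step measured on one core is an unsafe guide to the same change on the other, but it does not show which difference between the cores accounts for the gap.

The compounds shown leave open how an amine or a carboxylic acid on that aromatic carbon would read on either core. Also open, on these data alone, is how large this step would be on a third core.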